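The compounds below may be only part of what the source reports. "The series", "measured", "known", "first", "only" and "open" are said of these compounds alone.

Measured in a functional assay on MDA-MB-231 cells (Homo sapiens) for antiproliferative activity, read by MTT assay, with a stated time of 72 h; on this read-out higher numbers stand for weaker inhibition and lower numbers for stronger inhibition:
- compound 1 `COc1cc(OC)cc(-c2cccc(NC(=O)CCc3cccc4c3B(O)OC4)c2)c1`: 40 nM
- compound 2 `O=C(CCc1cccc2c1B(O)OC2)Nc1cccc(-c2ccc(C(F)(F)F)cc2)c1`: 510 nM
- compound 3 `COc1cccc(-c2cccc(NC(=O)CCc3ccc4c(c3)B(O)OC4)c2)c1`: 49000 nM

Compound 3, at 49000 nM, has the highest number of the three and lies beyond the scatter from both others. Compound 4 `COc1cc(OC)cc(-c2cccc(NC(=O)CCc3ccc4c(c3)B(O)OC4)c2)c1` differs from it in one place: methoxy in place of hydrogen on an aromatic carbon. This is methoxy in place of hydrogen on an aromatic carbon, turning 3-methoxyphenyl into 3,5-dimethoxyphenyl.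

For the measured compounds named here, one measured step bears on this, and only indirectly: a 13-fold higher number from compound 1 to compound 2 (1.11 log units; beyond the scatter). It is large, but it replaces the whole 3,5-dimethoxyphenyl with 4-(trifluoromethyl)phenyl on the core of compound 1, so it does not isolate a single methoxy. Compound 4 shares its 3,5-dimethoxyphenyl with compound 1 but not the core, so compound 1 at 40 nM sets no target. A lower number in this assay is expected, by a step somewhat smaller than the measured one. The expected step is a 4.1-fold lower number from compound 3 to compound 4 (0.61 log units; beyond the scatter). Compound 4 is estimated at 12000 nM, with an expected range of 2000 nM to 50000 nM.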

Compound 4, half-maximal inhibitory concentration: 21000 nM
Compound 4: the middle estimate sits 1.8-fold (0.24 log units) below what was measured; the range from low to high includes it.
By their numbers in this assay, from the lowest: compound 1; then compound 2; then compound 4; then compound 3.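

In this assay, for the compounds shown here, adding a methoxy to turn 3-methoxyphenyl into 3,5-dimethoxyphenyl gives a 2.3-fold lower number from compound 3 to compound 4 (0.37 log units; beyond the scatter) and so isolates a single methoxy for the first time: a modest step, but beyond the scatter. With the 3,5-dimethoxyphenyl held constant, the exchange of one core for the other gives a 530-fold higher number from compound 1 to compound 4 (2.72 log units; beyond the scatter) and so outweighs the methoxy step by a wide margin in this pair of comparisons. No accompanying evidence bears on either step.

As far as these compounds go, it remains open whether the methoxy step carries over to the core of compound 1, where the series has its lowest numbers. Also open, from the compounds shown here alone, is whether a hydroxy group or an amine on this same aromatic carbon would move the number in the same direction as methoxy.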